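Notes on the series: from compound 3 to compound 4

The source may hold more compounds than are shown below. What is called first, only, known or untested is meant among the compounds shown, and "the series" means these compounds.

Values in a functional assay on MCF7 cells (Homo sapiens) for cytotoxicity; a lower number here means a stronger inhibitor of growth, a higher number a weaker inhibitor of growth:
- compound 1 `COc1ccc(NS(=O)(=O)c2c(F)c(F)c(F)c(F)c2Br)cc1` 39 nM
- compound 2 `COc1ccc(NS(=O)(=O)c2c(F)c(F)c(Br)c(F)c2F)cc1` 36000 nM
- compound 3 `COc1ccc(NS(=O)(=O)c2c(F)c(F)cc(F)c2F)cc1` > 50000 nM
- compound 4 `COc1ccc(NS(=O)(=O)c2c(F)c(F)c(F)c(F)c2F)cc1` not yet measured

Compound 3 has no number, only a limit of the assay: > 50000 nM. The change to compound 4 is fluoro in place of hydrogen on an aromatic carbon, para to a large group.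

For the measured compounds named here, the one measured step at that carbon, hydrogen in place of bromo, is an at least 1.3-fold higher number from compound 2 to compound 3 (0.14 log units; that floor lies within the scatter). Fluoro sits at that carbon in compound 1, which gives 39 nM, a far lower number than compound 2 at 36000 nM with bromo there. Compound 4 shares that fluoro, so its number is expected to lie close to compound 1 at 39 nM. Going by the values given here, the other bromo of compound 1 is absent from compound 4, and no measured step covers that loss, so the range stays wide.

A large move to a lower number is expected in this assay, estimated as an at least 830-fold lower number from compound 3 to compound 4 (2.92 log units; beyond the scatter). The estimate for compound 4 is 60 nM, with an expected range of 15 nM to 400 nM.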

Compound 4, concentration for 50% growth inhibition: 29 nM
For compound 4 the middle estimate is 2.1-fold (0.32 log units) above the measured one; the range from low to high includes it.
By their numbers in this assay, from the lowest: compounds 4 and 1 (each within the scatter of the next); then compound 2. At a limit, above all of these: compound 3.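

In this assay, fluoro in place of hydrogen on the aromatic carbon para to a large group gives an at least 1700-fold lower number from compound 3 to compound 4 (3.23 log units; beyond the scatter), and fluoro in place of bromo on that carbon gives a 1200-fold lower number from compound 2 to compound 4 (3.09 log units; beyond the scatter), so of the three groups shown there, only fluoro goes with a low number. The other bromo of compound 1 is not needed for a low number, since fluoro in its place gives a 1.3-fold lower number from compound 1 to compound 4 (0.13 log units; within the scatter). Compound 3 carries only a limit of the assay, > 50000 nM, so the true size of its step is unknown: the limit of > 50000 nM in this assay, at which 1 of the 4 values shown sits.

For the compounds shown here, whether fluoro is the only group tolerated on this carbon stays open, as a chloro, a methoxy, a nitrile or an amine there could give either result. Also open, as far as these compounds go, is whether the large step at this carbon holds when the other fluoro groups are replaced by hydrogen.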